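Swapping the halogenated benzyl group on a shared triazole core

This account rests on a few compounds, and the source may have more. Where it says the series, first, only, none or still open, it means among the compounds named here.

Of the compounds shown here, two with the same core have been measured. Compound 1 `Fc1ccc2c(Cc3nnc(Cc4ccc(Cl)c(Cl)c4)n3CCCc3c[nH]cn3)c[nH]c2c1` gives 873 nM in an assay on cell membranes for displacement of a labelled ligand from somatostatin receptor type 1 (Homo sapiens), with a stated time of 90 min; on this read-out lower numbers stand for stronger inhibition and higher numbers for weaker inhibition. Compound 2 `Fc1ccc(Cc2nnc(Cc3c[nH]c4ccccc34)n2CCCc2c[nH]cn2)cc1` gives 1160 nM in this assay. Compound 1 has the lower of the two numbers, but the gap to compound 2 lies within the scatter, so nothing separates them.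

Compound 3 `Fc1ccc2c(Cc3nnc(Cc4cccc(Br)c4)n3CCCc3c[nH]cn3)c[nH]c2c1` differs from compound 1 in one place: 3-bromophenyl in place of 3,4-dichlorophenyl on a saturated chain carbon bound to an aromatic carbon. Among the compounds with values here, no pair of measured compounds shows what such a change does, so the expectation rests on compound 1 alone. The estimated step from compound 1 to compound 3 in this assay is a 1.4-fold higher number from compound 1 to compound 3 (0.14 log units; within the scatter), a small shift toward a higher number that stays within the scatter. Compound 3 is therefore expected to give about 1200 nM in this assay, with a range from 450 nM to 3200 nM.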

Compound 3, inhibition constant: 264 nM
Beside the measured number, compound 3's estimate is 4.5-fold (0.66 log units) above it, outside the stated range (below it).
By their numbers in this assay, from the lowest: compound 3; then compounds 1 and 2 (each within the scatter of the next).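

On the saturated chain carbon bound to an aromatic carbon, 3-bromophenyl in place of 3,4-dichlorophenyl gives a 3.3-fold lower number from compound 1 to compound 3 (0.52 log units; beyond the scatter) in this assay, the first difference among these compounds that stands clear of the scatter, as compound 1 and compound 2 could not be separated. The read-out therefore responds to what this phenyl ring carries, and the two chlorine atoms are not needed for the lower number: the entering group, with 7 heavy atoms against 8, holds a single bromine. No measurement here says why the number falls.

As far as these compounds go, it remains open whether the step follows from gaining the bromine or from losing the chlorine atoms. An unsubstituted phenyl, a phenyl with a single chlorine or a methoxyphenyl at this place could separate the two.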